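Compound 3 to compound 4: one aromatic group exchanged

A few compounds are considered here, and "the series" means these few. Any claim that something is new, unique, unknown or untested is made for them only; others in the source may bear on it.

In an ADME assay on the whole organism (Mus musculus, strain BALB/c) for pharmacokinetics, read by LC-MS, with a stated time of 24 h, at a dose of 1 mg/kg by the intravenous route (a higher number here means more compound in the circulation at the dose given, a lower number less compound in the circulation), compound 3 `O=S(=O)(Nc1nccs1)c1ccc2c(c1)OCC[C@@H]2c1ccc(C(F)(F)F)cc1-n1ccnn1` gives 2200 nM, within the scatter of compound 1 `O=S(=O)(Nc1ncccn1)c1ccc2c(c1)OCC[C@@H]2c1ccc(C(F)(F)F)cc1-c1ccc(F)nc1` at 2000 nM and of compound 2 `Cn1nccc1-c1cc(C(F)(F)F)ccc1[C@H]1CCOc2cc(S(=O)(=O)Nc3nccs3)ccc21` at 1300 nM. Compound 4 `O=S(=O)(Nc1nccs1)c1ccc2c(c1)OCC[C@@H]2c1ccc(C(F)(F)F)cc1-c1ccc(F)nc1` carries 6-fluoropyridin-3-yl in place of 1H-1,2,3-triazol-1-yl on an aromatic carbon. Compound 1 carries 6-fluoropyridin-3-yl as well. For the measured compounds named here, the only measured exchange at this place is a 1.7-fold higher number from compound 2 to compound 3 (0.23 log units; within the scatter), so no step beyond the scatter is expected in this assay. The expected step is a 1.2-fold lower number from compound 3 to compound 4 (0.06 log units; within the scatter), in no firm direction. Compound 4 is estimated at 1900 nM, with an expected range from 1100 nM to 3300 nM.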

Compound 4, maximal plasma concentration in the Mus musculus assay: 800 nM
For compound 4 the middle estimate is 2.4-fold (0.38 log units) above the measured one; measured number below the stated range.
By their numbers in the Mus musculus assay, from the lowest: compounds 4, 2, 1 and 3 (each within the scatter of the next, the first and the last beyond it).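

In the Mus musculus assay, this position now gives a step beyond the scatter, a 2.8-fold lower number from compound 3 to compound 4 (0.44 log units; beyond the scatter), while a 1.6-fold lower number from compound 2 to compound 4 (0.21 log units; within the scatter) stays within it. The sulfonamide nitrogen matters as well: in the Mus musculus assay, with 6-fluoropyridin-3-yl held constant, the exchange gives a 2.5-fold lower number from compound 1 to compound 4 (0.40 log units; beyond the scatter). In a physicochemical assay for lipophilicity (on this read-out lower numbers stand for lower lipophilicity and higher numbers for higher lipophilicity), compound 3 gives 2.3 and compound 4 gives 3.2. The lower number from the aromatic exchange comes with higher lipophilicity: the measured distribution coefficient of compound 3, 2.3, and of compound 4, 3.2, a number 0.90 log units higher (beyond the scatter)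

From the compounds shown here alone, that link rests on this single pair, so it remains open whether lipophilicity accounts for the step. Also open, going by these compounds, is how an amine or a carboxylic acid at this position would read.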